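The compounds below may be only part of what the source reports. "The series", "measured", "known", "first", "only" and "open" are said of these compounds alone.

Measured compounds:
- Compound 1, `Cc1ccc(CNC(=O)c2cccc(C(C)Oc3cccnc3Nc3cnn(CC(C)(C)O)c3)c2)cc1`: 9100 nM
- Compound 2, `Cc1ccc(CNC(=O)c2cccc(C(C)Oc3cccnc3Nc3cnn(CC#N)c3)c2)cc1`: 38400 nM
- Compound 3, `Cc1ccc(CNC(=O)c2cccc(C(C)Oc3cccnc3Nn3cnnc3)c2)cc1`: 23700 nM

These three compounds were tested in a functional assay on NCI-H3122 cells (Homo sapiens) for antiproliferative activity, read by MTT assay, with a stated time of 48 h; on this read-out higher numbers stand for weaker inhibition and lower numbers for stronger inhibition. Compound 3 gives 23700 nM, the second highest of the three numbers. Its nearest neighbour is compound 2, and the step of a 1.6-fold lower number from compound 2 to compound 3 (0.21 log units; within the scatter) lies within the scatter, so the two cannot be told apart. Compound 1 stands further away: the step of a 2.6-fold higher number from compound 1 to compound 3 (0.42 log units; beyond the scatter) is modest but beyond the scatter, so compound 1 has the lower number of the pair.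

Compound 4, `Cc1ccc(CNC(=O)c2cccc(C(C)Oc3cccnc3Nc3nncs3)c2)cc1`, has not yet been measured. It differs from compound 3 in one place: 1,3,4-thiadiazol-2-yl in place of 4H-1,2,4-triazol-4-yl on a nitrogen on an aromatic ring. Both groups are small five-membered aromatic rings with three hetero atoms and the same count of hydrogen-bond acceptors.

Within the data shown here, none of the measured steps makes exactly this swap. The steps of a 2.6-fold higher number from compound 1 to compound 3 (0.42 log units; beyond the scatter) and a 1.6-fold lower number from compound 2 to compound 3 (0.21 log units; within the scatter) show that exchanging one small heteroaromatic group for another at this nitrogen moved the number only modestly or not beyond the scatter. A step of similar small size is therefore expected for a 1.2-fold lower number from compound 3 to compound 4 (0.07 log units; within the scatter), with no confident direction. Compound 4 is estimated at 20000 nM, within a range of 7000 nM to 60000 nM.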

Compound 4, half-maximal inhibitory concentration: 20800 nM
For compound 4 the middle estimate is 1.0-fold (0.02 log units) below the measured one; low and high end bracket the measured number.
By their numbers in this assay, from the lowest: compound 1; then compounds 4, 3 and 2 (each within the scatter of the next).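

At this nitrogen, 1,3,4-thiadiazol-2-yl in place of 4H-1,2,4-triazol-4-yl gives a 1.1-fold lower number from compound 3 to compound 4 (0.06 log units; within the scatter) in this assay, so exchanging a ring of 2 carbon and 3 nitrogen atoms for one of 2 carbon, 2 nitrogen and 1 sulfur atom leaves no difference that can be read in this assay. The new ring also cannot be told apart from the cyanomethyl-bearing pyrazole, with a 1.8-fold lower number from compound 2 to compound 4 (0.27 log units; within the scatter), whereas 1-(2-hydroxy-2-methylpropyl)-1H-pyrazol-4-yl remains separate, with a 2.3-fold higher number from compound 1 to compound 4 (0.36 log units; beyond the scatter), a modest step and the only one of the three beyond the scatter. Nothing measured here explains this pattern.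

The four compounds leave open whether the edge held by compound 1 comes from its hydroxyl-bearing chain or from the pyrazole ring that carries it, since compound 2 shares that ring and compound 4 does not. An amine or a carboxylic acid at the end of that chain, or a longer chain carrying the same hydroxyl, would test this, and the direction of any such change cannot be told from these numbers.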